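The source may hold more compounds than are shown below. What is called first, only, known or untested is meant among the compounds shown, and "the series" means these compounds.

Measured compounds:
Compound 1, `CC[C@@]1(c2ccccc2)OCC[C@@H](CCNCc2ccccc2)O1`, gives 20 nM in an assay on brain for displacement of a labelled ligand from Sigma non-opioid intracellular receptor 1 (Cavia porcellus); on this read-out higher numbers stand for weaker inhibition and lower numbers for stronger inhibition.
Compound 2, `c1ccc(CNCC[C@@H]2CCO[C@H](c3ccccc3)O2)cc1`, gives 6 nM.

Among the compounds with values here, compound 2 stands at the lower of the two numbers, and the only step known leads to it: a 3.3-fold lower number from compound 1 to compound 2 (0.52 log units; beyond the scatter). Compound 3, `C[C@@]1(c2ccccc2)OCC[C@@H](CCNCc2ccccc2)O1`, has not yet been measured. Its change from compound 2 is methyl in place of hydrogen on a saturated ring carbon, at the saturated ring carbon that carries an ethyl in compound 1. Within the data shown here, the one step that bears on it runs the other way: taking the ethyl away lowered the number, so putting a methyl, a smaller group than ethyl, onto this carbon is expected to raise it, though by less than the full ethyl did. For compound 3 a modest step upward is expected, a 1.7-fold higher number from compound 2 to compound 3 (0.22 log units; within the scatter). The estimate for compound 3 in this assay is 10 nM, with a likely range from 4 nM to 30 nM.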

Compound 3, inhibition constant: 17 nM
Compound 3: the middle estimate sits 1.7-fold (0.23 log units) below what was measured; the measured number falls inside the stated range.
By their numbers in this assay, from the lowest: compound 2; then compounds 3 and 1 (each within the scatter of the next).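

In this assay, one added carbon on the saturated ring carbon between two ring oxygen atoms is enough to shift the result beyond the scatter, with methyl in place of hydrogen giving a 2.8-fold higher number from compound 2 to compound 3 (0.45 log units; beyond the scatter). Extending that methyl to the ethyl gives no readable further change, as the step runs a 1.2-fold lower number from compound 1 to compound 3 (0.07 log units; within the scatter), so among these compounds the difference lies between hydrogen and either small chain, not between the two chains. Nothing available explains why this carbon responds in this way. The compounds shown leave open whether a longer chain such as propyl, or an oxygen-bearing group such as methoxy, at this carbon would match methyl and ethyl or move the number further. Also open, as far as these compounds go, is whether methyl would give a similar step with the opposite spatial arrangement at this carbon.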